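A Methyl Group Tried Where Methoxy and Phenyl Already Helped

The source may report more compounds than this note shows. Statements on the series, on what has been measured and on what is new or still open speak of the compounds shown alone.

Compound 1 `O=C(O)CCc1ccc(C#Cc2ccnc(-c3ccccc3)c2)cc1` gives 186 nM in an in vitro functional assay on 1321-N1 cells for agonist activity at Free fatty acid receptor 1 (Homo sapiens), read by fluorescence, spectrophotometry and calcium flux; on this read-out lower numbers stand for an effect already at smaller amounts and higher numbers for an effect only at larger amounts of compound. Compound 2 `COc1cc(C#Cc2ccc(CCC(=O)O)cc2)ccn1` gives 525 nM. Compound 3 `O=C(O)CCc1ccc(C#Cc2ccncc2)cc1` gives 4070 nM.

Compound 3 stands at the highest number of the three, so it needs the largest amount to act. Compound 4 `Cc1cc(C#Cc2ccc(CCC(=O)O)cc2)ccn1` differs from it by methyl in place of hydrogen on an aromatic carbon. Among the compounds with values here, two measured steps touch the same position: from compound 2 to compound 3 the number rose by a 7.8-fold higher number from compound 2 to compound 3 (0.89 log units; beyond the scatter), and from compound 1 to compound 3 it rose by a 22-fold higher number from compound 1 to compound 3 (1.34 log units; beyond the scatter). Both substituents placed there lowered the number; methyl is a smaller group than either, so a modest lowering is expected, by about a 4.1-fold lower number from compound 3 to compound 4 (0.61 log units; beyond the scatter). Compound 4 is therefore estimated at 1000 nM, within a range of 350 nM to 2800 nM.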

Compound 4, half-maximal effective concentration: 1120 nM
The estimate for compound 4 lay 1.1-fold (0.05 log units) below the measured number; the measured number falls inside the stated range.
By their numbers in this assay, from the lowest: compound 1; then compound 2; then compound 4; then compound 3.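

A single methyl next to the ring nitrogen already brings a 3.6-fold lower number from compound 3 to compound 4 (0.56 log units; beyond the scatter) and so gives a clear gain over hydrogen. It does not match the other two groups at this place: methoxy keeps a small edge, seen in a 2.1-fold higher number from compound 2 to compound 4 (0.33 log units; beyond the scatter) as the change runs back to methyl, and phenyl keeps a wider one, seen in a 6.0-fold higher number from compound 1 to compound 4 (0.78 log units; beyond the scatter) for the same change. The four compounds thus order as phenyl, methoxy, methyl, hydrogen from the lowest number, and nothing available explains that order.

As far as these compounds go, whether an ethyl group or an amine here would fall between methyl and methoxy remains open. So does whether a chlorine atom would fit the same order.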